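Amide nitrogen substituent swap on a shared core

The compounds below may be only part of what the source reports. "The series", "measured", "known", "first", "only" and "open" are said of these compounds alone.

Compound 1 `C=CC1=C(C(=O)Nc2ccccc2OC)C(c2ccc(Cl)c(Cl)c2)OC1` carries a 2-methoxyphenyl on its amide nitrogen together with a dichlorophenyl group. In a functional assay on HeLa cells (Homo sapiens) for cytotoxicity, read by MTT assay, with a stated time of 24 h (a lower number here means a stronger inhibitor, a higher number a weaker inhibitor), compound 1 gives > 100000 nM, which is a limit of the measurement and not a number. Compound 2 `C=CC1=C(C(=O)NCC(C)C)C(c2ccc(OC)cc2)OC1` carries an isobutyl on the amide nitrogen and a methoxyphenyl group on the shared core. In this assay compound 2 gives > 100000 nM, again a limit and not a number. Both values therefore sit at the same boundary, as noted in the limit of > 100000 nM in this assay, at which 2 of the 2 values shown sit, and no ordering between compound 1 and compound 2 can be read from them.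

Compound 3 `C=CC1=C(C(=O)Nc2ccccc2OC)C(c2ccc(OC)cc2)OC1` combines the 2-methoxyphenyl amide of compound 1 with the methoxyphenyl group of compound 2. The change from compound 2 is 2-methoxyphenyl in place of isobutyl on an amide-type nitrogen, in words: 2-methoxyphenyl in place of isobutyl on an amide-type nitrogen. No measured step is shown for this change, and the closest measured compounds both sit at the limit, so in this assay no step beyond the scatter is expected for compound 3, and the step that the limit leaves unreadable from compound 2 to compound 3 is estimated as essentially none. In this assay compound 3 is expected to give about 150000 nM, within 50000 nM to 500000 nM, most likely reported again only as a limit.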

Compound 3, half-maximal inhibitory concentration: > 100000 nM
Compound 3: no number, only a limit; the forecaster's own chance of this, stated with the estimate: 85%; the middle value is on the limit's open side.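

No step can be read between compound 3 and either compound 1 or compound 2, because all three values are limits and not numbers: the limit of > 100000 nM in this assay, at which 3 of the 3 values shown sit.

The compounds shown leave open whether any group on the amide nitrogen or on the saturated ring carbon of the shared core gives a readable number in this assay.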